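Replacing the dimethylphenyl amine of compound 1 with a fluorophenyl amine

A few compounds are considered here, and "the series" means these few. Any claim that something is new, unique, unknown or untested is made for them only; others in the source may bear on it.

Among the measured compounds shown here, compound 1 `Cc1ccc(NC2=CC(=O)c3nc4n(c3C2=O)[C@H]2OC[C@@H](O)[C@H]2OC4)cc1C` stands as the only compound with a true number in a functional assay on ECa-109 cells for inhibition, with ECa-109 cell line (Homo sapiens) as the target, read by sulforhodamine B assay (on this read-out lower numbers stand for stronger inhibition and higher numbers for weaker inhibition), where compound 1 gives 2820 nM. Compound 2 `Cc1ccc(NC2=CC(=O)c3c(nc4n3[C@H]3OC[C@@H](O)[C@H]3OC4)C2=O)cc1` reaches only a limit of this assay, > 4000 nM. Compound 3 `O=C1C(N2CCC2)=CC(=O)c2c1nc1n2[C@H]2OC[C@@H](O)[C@H]2OC1` likewise reaches only a limit, > 16000 nM. For the measured compounds named here, the single measured step, a step that the two limits leave unreadable from compound 2 to compound 3, runs between the limit of > 4000 nM in this assay, at which 1 of the 3 values shown sits, and the limit of > 16000 nM in this assay, at which 1 of the 3 values shown sits, and therefore cannot be read. Compound 4 `O=C1C=C(Nc2ccccc2F)C(=O)c2c1nc1n2[C@H]2OC[C@@H](O)[C@H]2OC1` carries 2-fluorophenyl in place of 3,4-dimethylphenyl on an amine nitrogen. Going by the values given here, no measured step bears on this change; the nearest comparison is compound 2, which carries (4-methylphenyl)amino and does not reach a number. Compound 4 is therefore expected to be somewhat weaker, at about 5500 nM, between 1800 nM and 18000 nM. The expected step of a 2.0-fold higher number from compound 1 to compound 4 (0.29 log units; within the scatter) is a modest loss, with a real chance of a limit only.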

Compound 4, half-maximal inhibitory concentration: 2760 nM
Compound 4: middle estimate off by 2.0-fold (0.30 log units), on the high side; the measured number falls inside the stated range.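

In this assay the change gives a 1.0-fold lower number from compound 1 to compound 4 (0.01 log units; within the scatter), the first step among these compounds that can be read. On this amine nitrogen, then, 2-fluorophenyl and 3,4-dimethylphenyl give values within the usual scatter of each other, so the phenyl ring can lose both methyl groups and gain a fluorine with no readable change in this read-out. Nothing shown gives a cause for this result. Going by these compounds, what a benzyl group, a pyridyl ring or a phenyl ring bearing a carboxylic acid would give on this nitrogen stays open.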